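Moving the chlorine on the urea-bound aryl ring

The compounds below may be only part of what the source reports. "The series", "measured", "known", "first", "only" and "open" are said of these compounds alone.

Measured in an assay on isolated protein for inhibition of Polyunsaturated fatty acid 5-lipoxygenase (Homo sapiens), read by HPLC, with a stated time of 10 min; a higher number here means a weaker inhibitor, a lower number a stronger inhibitor:
compound 1, `Cc1cc(OCc2nc3ccccc3s2)ccc1NC(=O)Nc1ccc(Cl)c(Cl)c1`, 230 nM
compound 2, `Cc1cc(OCc2nc3ccccc3s2)ccc1NC(=O)Nc1cccc(Cl)c1`, 160 nM

Compound 2 holds the lower of the two numbers in this assay, and its nearest neighbour is compound 1; the step of a 1.4-fold lower number from compound 1 to compound 2 (0.16 log units; within the scatter) is within the scatter, so the two are not ordered by it. Compound 3, `Cc1cc(OCc2nc3ccccc3s2)ccc1NC(=O)Nc1ccc(Cl)cc1`, is not yet measured. It differs from compound 2 only by 4-chlorophenyl in place of 3-chlorophenyl on an amide-type nitrogen. For the measured compounds named here, no measured step touches this change: the one step available removes a chlorine from the ring that carries it, rather than moving one, so it gives no direct guide. Going by the values given here, the only piece of evidence is that adding or removing the second chlorine left the number within the scatter, which suggests this part of the molecule does not swing the result strongly. The estimate for compound 3 therefore stays close to compound 2, with the step of a 1.1-fold higher number from compound 2 to compound 3 (0.05 log units; within the scatter) expected to fall within the scatter. Compound 3 is estimated at 180 nM, with a range from 70 nM to 450 nM.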

Compound 3, half-maximal inhibitory concentration: 570 nM
For compound 3 the middle estimate is 3.2-fold (0.50 log units) below the measured one, and the stated range ends below it.
By their numbers in this assay, from the lowest: compounds 2 and 1 (each within the scatter of the next); then compound 3.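

In this assay, moving the single chlorine, with 4-chlorophenyl in place of 3-chlorophenyl on an amide-type nitrogen, gives a 3.6-fold higher number from compound 2 to compound 3 (0.55 log units; beyond the scatter), so at this position the placement of the chlorine changes the number even though the atoms stay the same. Removing a chlorine from the ring of compound 1 also proves to depend on which one goes: the earlier removal gave a 1.4-fold lower number from compound 1 to compound 2 (0.16 log units; within the scatter), whereas the removal that leaves the 4-chlorophenyl group gives a 2.5-fold higher number from compound 1 to compound 3 (0.39 log units; beyond the scatter), and so the earlier impression that this ring hardly affects the result holds only for the first of these two removals. Nothing shown here accounts for this difference between the two placements of the chlorine.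

The compounds shown carry only chlorine on this ring, so it remains open whether a fluorine, a methoxy group or a nitrile would show the same dependence on placement. Also open, from the compounds shown here alone, is how a plain phenyl ring with no chlorine at all would compare with compound 2 and compound 3.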